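Isoindoline hydroxamic acids: nitrogen substituent and antiproliferative activity

A few compounds are considered here, and "the series" means these few. Any claim that something is new, unique, unknown or untested is made for them only; others in the source may bear on it.

Measured compounds:
compound 1, `CC(C)(C)C(=O)N1Cc2ccc(/C=C/C(=O)NO)cc2C1`, "not determined" (no result reported)
compound 2, `O=C(/C=C/c1ccc2c(c1)CN(S(=O)(=O)c1cccnc1)C2)NO`, 4260 nM

Compound 1 is the reference point of this step, yet in a functional assay on HCT-116 cells (Homo sapiens) for antiproliferative activity (a lower number here means a stronger inhibitor, a higher number a weaker inhibitor), compound 1 has no single number, so its standing on the scale cannot be placed from what is shown. The only measured point in the set is compound 2, which shares the core and carries a sulfonyl group on the ring nitrogen; in this assay compound 2 gives 4260 nM, which sits in the weak range.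

The unmeasured compound 3, `O=C(/C=C/c1ccc2c(c1)CN(Cc1ccccc1)C2)NO`, is reached from compound 1 by the change (benzyl in place of (tert-butyl)carbonyl on an amine nitrogen in a ring). For the measured compounds named here, with no measured pair on this change, and no value for compound 1 itself, no measured step can be cited. The expectation for the step in this assay is therefore loose: a modest shift, in either direction, is as plausible as none beyond the scatter, and the value of compound 2 is taken as the anchor for the size of the numbers.

For compound 3 the expected half-maximal inhibitory concentration in this assay is estimated at 3000 nM, with a range from 800 nM to 12000 nM.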

Compound 3, half-maximal inhibitory concentration: 1040 nM
The estimate for compound 3 lay 2.9-fold (0.46 log units) above the measured number; measured number inside the range.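

In this assay, for the compounds shown here, compound 1 carries no single number, so no step from compound 1 to compound 3 can be read. The compounds shown leave open how benzyl and (tert-butyl)carbonyl on the ring nitrogen compare in this assay on the shared core. No measured evidence bears on the result.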